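A few compounds are considered here, and "the series" means these few. Any claim that something is new, unique, unknown or untested is made for them only; others in the source may bear on it.

Compound 2 `COc1ccc(/C=C/C2CC=CC(=O)N2)cc1` is one of two measured members of a small series whose other member is compound 1 `O=C1C=CCC(/C=C/c2ccccc2)N1`. In a functional assay on HT-29 cells (Homo sapiens) for inhibition, read by sulforhodamine B assay, with a stated time of 48 h (on this read-out higher numbers stand for weaker inhibition of growth and lower numbers for stronger inhibition of growth), compound 1 gives 1200 uM. In this assay compound 2 gives only a limit, > 1090 uM, so on the numbers shown compound 2 stands not at a value but at the ceiling of the assay. The step that the limit leaves unreadable from compound 1 to compound 2 therefore cannot be read in size, since the limit of > 1090 uM in this assay, at which 1 of the 2 values shown sits, hides where compound 2 truly lies.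

The next compound, compound 3 `COc1ccc(/C=C/C2CC=CC(=O)N2)cc1OC`, differs from compound 2 by methoxy in place of hydrogen on an aromatic carbon. Among the measured compounds shown here, the only measured step that bears on this change is the one from compound 1 to compound 2, which introduces a methoxy in place of hydrogen on an aromatic carbon in the same way, yet its size is unreadable, so no direction and no size beyond the scatter can be drawn from it. The step from compound 2 to compound 3 is thus expected to be a step that the limit leaves unreadable from compound 2 to compound 3 at most, with a strong chance that only a limit is reported again. Compound 3 is accordingly estimated at 1100 uM in this assay, within a range from 500 uM to 2500 uM.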

Compound 3, concentration for growth inhibition (reported as GI): > 964 uM
Compound 3: only a limit was reported; the forecaster's own chance of this, stated with the estimate: 70%; the middle value is on the limit's open side.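

In this assay compound 3 gives only a limit, > 964 uM. Compound 2 also stands at a limit, so the step between compound 2 and compound 3 cannot be read in size. The compounds shown leave open whether methoxy in place of hydrogen on an aromatic carbon changes growth inhibition at all, and where compound 2 and compound 3 truly lie.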